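The compounds below may be only part of what the source reports. "The series", "measured", "known", "first", "only" and "open" are said of these compounds alone.

Measured so far:
compound 1 `CCCNC1=NS(=O)(=O)c2cccc(Cl)c2N1` — 180000 nM
compound 2 `CC(C)NC1=NS(=O)(=O)c2cccc(Cl)c2N1` — > 300000 nM
compound 3 `CCCNC1=NS(=O)(=O)c2ccc(Cl)cc2N1` — 73200 nM

In a functional assay on aorta (Rattus norvegicus) for inhibition (on this read-out lower numbers stand for an effect already at smaller amounts and higher numbers for an effect only at larger amounts of compound), compound 1 gives 180000 nM. For compound 2 the read-out is only a limit of the assay, (the limit of > 300000 nM in this assay, at which 1 of the 3 values shown sits). In this assay compound 3 gives 73200 nM, the lowest of the two numbers obtained. The difference between the core of compound 1 and the core of compound 3 is not broken down here. The change isopropyl in place of propyl on an amine nitrogen produced an at least 1.6-fold higher number from compound 1 to compound 2 (0.22 log units; that floor lies within the scatter). Compound 4 `CC(C)NC1=NS(=O)(=O)c2ccc(Cl)cc2N1` has not yet been measured; it carries the same change relative to compound 3, (isopropyl in place of propyl on an amine nitrogen), at the same place. Resting on the step from compound 1 to compound 2, compound 4 is expected to move by a 2.7-fold higher number from compound 3 to compound 4 (0.44 log units; beyond the scatter), with a fair chance of returning only a limit. The estimate for compound 4 in this assay is 200000 nM, expected between 90000 nM and 450000 nM.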

Compound 4, half-maximal effective concentration: 53400 nM
For compound 4 the middle estimate is 3.7-fold (0.57 log units) above the measured one; the whole stated range lies above it.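

In this assay isopropyl in place of propyl on an amine nitrogen gives a 1.4-fold lower number from compound 3 to compound 4 (0.14 log units; within the scatter) and so nothing that can be told from the scatter on the core of compound 3. Compound 2 at > 300000 nM is only a limit of the assay. Whether the change behaves alike on the two cores stays undecided, and neither a carried-over effect nor one that depends on the core is shown: the same change on two cores in this assay, an at least 1.6-fold higher number (0.22 log units; that floor lies within the scatter) from compound 1 to compound 2 and a 1.4-fold lower number (0.14 log units; within the scatter) from compound 3 to compound 4; the limit leaves it open whether they differ

Open, going by these compounds, is whether a longer chain such as butyl, or a cyclopropyl group, on the amine nitrogen would read apart from propyl and isopropyl on either core. Also open, on these data alone, is whether the same change would hold on a core carrying a methyl or methoxy group in place of the chlorine.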